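The source may hold more compounds than are shown below. What is called first, only, known or untested is meant among the compounds shown, and "the series" means these compounds.

Compound 1 `O=C(CCl)Nc1cccc(-c2nc3ccccc3s2)c1` is the starting point. In an ADME assay on Raji cells (Homo sapiens) for inhibition, with a stated time of 72 h (on this read-out lower numbers stand for an effect already at smaller amounts and higher numbers for an effect only at larger amounts of compound), compound 1 gives 1700 nM, the lowest of the two numbers shown. Compound 2 `O=C(Nc1cccc(-c2nc3ccccc3s2)c1)c1cnccc1Cl` gives 12000 nM in this assay. For compound 3 `O=C(Nc1cccc(-c2nc3ccccc3s2)c1)c1ccnc(Cl)c1` this assay reports only a limit, > 25000 nM. The change to compound 4 `O=C(Nc1cccc(-c2nc3ccccc3s2)c1)c1ccncc1Cl` is 3-chloropyridin-4-yl in place of chloromethyl on a carbonyl carbon. Within the data shown here, two measured steps bear on it, both also swapping the chloromethyl for a chloropyridine on the carbonyl carbon: a 7.1-fold higher number from compound 1 to compound 2 (0.85 log units; beyond the scatter) and an at least 14-fold higher number from compound 1 to compound 3 (1.16 log units; beyond the scatter). A higher number in this assay is therefore expected for compound 4 as well, as a step of about an 8.8-fold higher number from compound 1 to compound 4 (0.95 log units; beyond the scatter). The estimate for compound 4 in this assay is 15000 nM, within a range from 5000 nM to 40000 nM.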

Compound 4, half-maximal effective concentration: > 25000 nM
Compound 4: no number, only a limit; the forecaster's own chance of this, stated with the estimate: 30%; at least 1.6-fold (0.22 log units) between middle value and limit.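

The result for compound 4 is a limit of the assay, not a number. Even so, 3-chloropyridin-4-yl in place of chloromethyl gives an at least 14-fold higher number from compound 1 to compound 4 (1.16 log units; beyond the scatter), so all three chloropyridines shown read higher than the chloromethyl group, and swapping 4-chloropyridin-3-yl for 3-chloropyridin-4-yl gives an at least 2.0-fold higher number from compound 2 to compound 4 (0.31 log units; beyond the scatter). The step between compound 3 and compound 4 cannot be read, since both results are limits: the limit of > 25000 nM in this assay, at which 2 of the 4 values shown sit.

Still open, as far as these compounds go, is how a longer chain ending in chlorine would compare with chloromethyl on the carbonyl carbon. From the compounds shown here alone, a pyridine ring carrying no chlorine also remains open.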